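Triazole-linked bicyclic lactams against pancreatic cancer cells

The source may hold more compounds than are shown below. What is called first, only, known or untested is meant among the compounds shown, and "the series" means these compounds.

Measured so far:
- compound 1, `CC1(C)[C@H]2CC[C@]1(C)N(Cc1cn(-c3cccc(F)c3)nn1)C(=O)C2`: 220 nM
- compound 2, `CC1(C)[C@H]2CC[C@]1(C)N(Cc1cn(-c3ccccc3F)nn1)C(=O)C2`: 150 nM

In a functional assay on PANC-1 cells (Homo sapiens) for inhibition, read by MTT assay, with a stated time of 24 h (on this read-out lower numbers stand for stronger inhibition and higher numbers for weaker inhibition), compound 2 gives the lowest of the two numbers, and its nearest neighbour is compound 1, which gives 220 nM. Within the data shown here, the only measured step, a 1.5-fold lower number from compound 1 to compound 2 (0.17 log units; within the scatter), moves a fluorine between two positions of the phenyl ring and stays within the scatter. Compound 3, `COc1cccc(-n2cc(CN3C(=O)C[C@@H]4CC[C@@]3(C)C4(C)C)nn2)c1`, is not yet measured; its change from compound 2 is 3-methoxyphenyl in place of 2-fluorophenyl on an aromatic nitrogen. Among the measured compounds shown here, no measured step shows what a methoxy group does here, so the only guide is that the single known change of the phenyl substituent, from compound 1 to compound 2, left the number essentially unchanged. On that basis the expected step is a 1.3-fold higher number from compound 2 to compound 3 (0.12 log units; within the scatter), with no shift beyond the scatter anticipated. Compound 3 is therefore estimated at 200 nM in this assay, in the range 70 nM to 600 nM.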

Compound 3, half-maximal inhibitory concentration: 860 nM
The estimate for compound 3 lay 4.3-fold (0.63 log units) below the measured number; measured number above the stated range.
By their numbers in this assay, from the lowest: compounds 2 and 1 (each within the scatter of the next); then compound 3.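

In this assay, the group on the phenyl ring matters more than the earlier pair suggested: changing the place of the fluorine stayed within the scatter, but the step to the methoxy compound, a 5.7-fold higher number from compound 2 to compound 3 (0.76 log units; beyond the scatter), does not. The closest comparison keeps the substituent in the same place on the phenyl ring and exchanges only fluoro for methoxy, and this step, a 3.9-fold higher number from compound 1 to compound 3 (0.59 log units; beyond the scatter), also shows weaker inhibition. Nothing available explains this loss of inhibition.

The compounds shown include only fluoro and methoxy on this phenyl ring, so it remains unclear whether the loss is specific to methoxy or would also occur with other groups, such as chloro, methyl or an amine. A 2-methoxyphenyl group would also show whether the ring place that carries methoxy affects the result.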